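Notes on the step from compound 1 to compound 3

The source may report more compounds than this note shows. Statements on the series, on what has been measured and on what is new or still open speak of the compounds shown alone.

Readings so far in a functional assay on HO8910 cells (Homo sapiens) for inhibition, read by MTT assay, with a stated time of 24 h, tested at 1 ug/mL (on this read-out lower numbers stand for less inhibition of growth and higher numbers for more inhibition of growth at the one concentration tested), for two compounds
compound 1 `O=C(O)CCCCC(CCSC(=O)c1ccccc1)SC(=O)c1ccccc1` gives 0.29%
compound 2 `O=C(CCCCC1CCSS1)Nc1cccc2ccccc12` gives 6.95%

Compound 1 (0.29%) stands within the scatter of compound 2 (6.95%), so the two cannot be ranked. Compound 3 `O=C(CCCCC(CCSC(=O)c1ccccc1)SC(=O)c1ccccc1)Nc1ccc(Cl)cc1` differs from compound 1 by (4-chlorophenyl)amino in place of hydroxy on a carbonyl carbon with (4-chlorophenyl)amino in place of hydroxy on a carbonyl carbon. Within the data shown here, no measured step covers this change. A modest rise in this assay is expected, possibly none beyond the scatter, since compound 2 gives only 6.95% there. The estimated change is a number 8.7 percentage points higher from compound 1 to compound 3 (within the scatter) as a working figure. Compound 3 is expected at 9% (range 0% to 28%).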

Compound 3, percent growth inhibition at one concentration: 1.29%
Compound 3: the middle estimate sits 7.7 percentage points above what was measured, within the range that was stated.
By their numbers in this assay, from the lowest: compounds 1, 3 and 2 (each within the scatter of the next).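

In this assay, (4-chlorophenyl)amino in place of hydroxy on a carbonyl carbon gives a number 1 percentage points higher from compound 1 to compound 3 (within the scatter). Among these compounds, this is the first single-place step, and it does not separate the carboxy group from the (4-chlorophenyl)carbamoyl group on the core of compound 1. No available evidence bears on this result. Open, from the compounds shown here alone, is whether a simple amine such as benzylamine, joined at the same carbonyl carbon, would read differently. Also open, going by these compounds, is whether a longer chain would move this assay beyond the scatter.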